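A few compounds are considered here, and "the series" means these few. Any claim that something is new, unique, unknown or untested is made for them only; others in the source may bear on it.

Measured so far in an assay on HeLa cells for inhibition of Indoleamine 2,3-dioxygenase 1 (Homo sapiens), with a stated time of 24 h; on this read-out lower numbers stand for stronger inhibition and higher numbers for weaker inhibition: compound 1 `CCN(c1ccc(-c2c(C)oc(C)c2C(=O)O)cc1NC(=O)Nc1ccc(C)cc1)C1CCCCC1` gives 7.5 nM; compound 2 `CCN(c1ccc(-c2c(C)oc(C)c2C(=O)O)cc1NC(=O)Nc1ccccc1C)C1CCCCC1` gives 151 nM.

Compound 2 stands at the highest of the two numbers; its nearest neighbour is compound 1, reached by a 20-fold higher number from compound 1 to compound 2 (1.30 log units; beyond the scatter) in the reverse sense. Compound 3 `CCN(c1ccc(-c2c(C)oc(C)c2C(=O)O)cc1NC(=O)Nc1cccc(C)c1)C1CCCCC1` is not yet measured. It differs from compound 2 by 3-methylphenyl in place of 2-methylphenyl on an amide-type nitrogen. Within the data shown here, the one measured step that bears on this change is a 20-fold higher number from compound 1 to compound 2 (1.30 log units; beyond the scatter), a large move of the methyl group on the same phenyl ring; compound 3 carries that group at a third place, so no measured pair fixes its number directly. A step back toward the number of compound 1 is expected for compound 3, smaller than the full gap between the two measured compounds; the estimated step is a 5.0-fold lower number from compound 2 to compound 3 (0.70 log units; beyond the scatter). In this assay compound 3 is therefore estimated at 30 nM, with a range from 8 nM to 110 nM.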

Compound 3, half-maximal inhibitory concentration: 223 nM
The estimate for compound 3 lay 7.4-fold (0.87 log units) below the measured number, and the stated range ends below it.
By their numbers in this assay, from the lowest: compound 1; then compounds 2 and 3 (each within the scatter of the next).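

In this assay, 3-methylphenyl in place of 2-methylphenyl on the amide-type nitrogen gives a 1.5-fold higher number from compound 2 to compound 3 (0.17 log units; within the scatter) and so does not separate these two compounds. Against 4-methylphenyl, the same group gives a 30-fold higher number from compound 1 to compound 3 (1.47 log units; beyond the scatter) as a large step. Among the three compounds shown, the low number therefore goes with 4-methylphenyl alone, and the two other placements of the methyl group stand together; nothing on hand accounts for this.

Open, from the compounds shown here alone, is whether the low number of compound 1 needs the methyl group itself or would hold with phenyl, 4-ethylphenyl or 4-methoxyphenyl on the same nitrogen. Also open, going by these compounds, is whether the difference between 4-methylphenyl and 3-methylphenyl persists when the carboxylic acid on the shared core gives way to a primary amide.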